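Urea-linked quinazoline series: antiproliferative readings, next step

The source may report more compounds than this note shows. Statements on the series, on what has been measured and on what is new or still open speak of the compounds shown alone.

compound 1 `COc1ccc(NC(=O)Nc2cccc(CNc3ncnc4ccccc34)c2)cc1` — 29300 nM
compound 2 `COc1cc2ncnc(NCc3cccc(NC(=O)Nc4ccccc4C)c3)c2cc1OC` — 21400 nM

In a functional assay on A549 cells (Homo sapiens) for antiproliferative activity, read by MTT assay (a lower number here means a stronger inhibitor, a higher number a weaker inhibitor), compound 1 gives 29300 nM and compound 2 gives 21400 nM. Compound 2 stands at the lower of the two numbers, but the gap to compound 1 is within the scatter, so the two cannot be separated. Both are weak inhibitors.

Compound 3 `COc1cc2ncnc(NCc3cccc(NC(=O)Nc4cccc(C(F)(F)F)c4)c3)c2cc1OC` differs from compound 2 in one place: 3-(trifluoromethyl)phenyl in place of 2-methylphenyl on an amide-type nitrogen. The exchange sits on an amide-type nitrogen whose other neighbour is a carbonyl carbon. For the measured compounds named here, no pair of measured compounds differs in this one place, and compound 1 and compound 2 differ in more than one place, so their gap gives no guidance for this exchange. In this assay the step is expected to be small, of the order of the scatter, with no settled direction: a 1.4-fold lower number from compound 2 to compound 3 (0.15 log units; within the scatter) is the expected step. Compound 3 is estimated at 15000 nM, within 4000 nM to 55000 nM.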

Compound 3, half-maximal inhibitory concentration: 35300 nM
For compound 3 the middle estimate is 2.4-fold (0.37 log units) below the measured one, within the range that was stated.
By their numbers in this assay, from the lowest: compounds 2, 1 and 3 (each within the scatter of the next).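

In this assay, for the compounds shown here, the exchange of 2-methylphenyl for 3-(trifluoromethyl)phenyl on the amide-type nitrogen gives a 1.6-fold higher number from compound 2 to compound 3 (0.22 log units; within the scatter) and provides the first reading at this position with the rest of the molecule unchanged. This position therefore accepts this exchange of one substituted phenyl group for another without a reading that can be separated from the scatter, and compound 2 and compound 3 both remain weak inhibitors. No measurement on hand bears on this result.

Open, on these data alone, is whether a group of another kind on this nitrogen, such as a pyridine ring, a carboxylic acid or a longer chain bearing an amine, would move the reading beyond the scatter. Also open, as far as these compounds go, is whether 3-(trifluoromethyl)phenyl would read the same on the core of compound 1.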